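Replacing the undecyl group of compound 2

A few compounds are considered here, and "the series" means these few. Any claim that something is new, unique, unknown or untested is made for them only; others in the source may bear on it.

Measured so far in an ADME assay on HII4E cells (Mus musculus) for cytotoxicity, read by MTT assay, with a stated time of 48 h; a lower number here means a stronger inhibitor, a higher number a weaker inhibitor
Compound 1 `CCOC(=O)/C=C1\C(OC(C)=O)=C[C@@H](COC(C)=O)O[C@@H]1OCC(=O)NCc1ccccc1` gives 128 ug/mL
Compound 2 `CCCCCCCCCCCCNC(=O)CO[C@H]1O[C@H](COC(C)=O)C=C(OC(C)=O)/C1=C\C(=O)OCC` gives 76 ug/mL

Among the compounds with values here, the only measured step is a 1.7-fold lower number from compound 1 to compound 2 (0.23 log units; within the scatter) and it lies within the scatter, so compound 2 stands level with its sole neighbour on these numbers. Compound 3 `CCOC(=O)/C=C1\C(OC(C)=O)=C[C@@H](COC(C)=O)O[C@@H]1OCC(=O)NCc1cn(Cc2ccccc2)nn1` is not yet measured. It carries 1-benzyl-1H-1,2,3-triazol-4-yl in place of undecyl on a saturated chain carbon bound to an amide-type nitrogen. Within the data shown here, only the step of a 1.7-fold lower number from compound 1 to compound 2 (0.23 log units; within the scatter) bears on this, as it changes the same place, and it stayed within the scatter. Among the measured compounds shown here, no compound carrying the entering group has been measured. In this assay no step beyond the scatter is therefore expected, and no direction can be argued. The estimated step is a 1.3-fold higher number from compound 2 to compound 3 (0.12 log units; within the scatter) and it fits that expectation. For compound 3 the expected value is 100 ug/mL with an estimated range from 40 ug/mL to 250 ug/mL as its span.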

Compound 3, half-maximal inhibitory concentration: 12000 ug/mL
Estimate against measurement, compound 3: 120-fold (2.08 log units) below, outside the stated range (above it).
By their numbers in this assay, from the lowest: compounds 2 and 1 (each within the scatter of the next); then compound 3.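

In this assay, the group on a saturated chain carbon bound to an amide-type nitrogen proves able to shift the number far beyond the scatter, which the earlier pair of compounds had not shown. Putting 1-benzyl-1H-1,2,3-triazol-4-yl in place of undecyl gives a 160-fold higher number from compound 2 to compound 3 (2.20 log units; beyond the scatter) and putting it in place of phenyl gives a 94-fold higher number from compound 1 to compound 3 (1.97 log units; beyond the scatter), so both steps are large and point the same way, towards a weaker inhibitor. Nothing available explains this change.

From the compounds shown here alone, whether the change belongs to the five-membered aromatic ring or to the six-membered aromatic ring of the entering group stays open. Also open, going by these compounds, is how a primary amine, a carboxylic acid or a chain longer than undecyl would read at this place.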